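The source may hold more compounds than are shown below. What is called first, only, known or untested is meant among the compounds shown, and "the series" means these compounds.

Working notes on the series. In a functional assay on NCI-H460 cells (Homo sapiens) for cytotoxicity, read by MTT assay, with a stated time of 72 h (a higher number here means a weaker inhibitor, a lower number a stronger inhibitor), compound 1 `CCCCCCCCCCCCCCC[C@@H](C[C@@H](O)C[C@@H](O)C[C@@H](O)C[C@@H](O)C[C@H]1CC=CC(=O)O1)OC(C)=O` gives 3800 nM and compound 2 `CCCCCCCCCCCCCCC[C@H](C[C@H](O)C[C@H](O)C[C@H](O)C[C@H](O)C[C@@H]1CC=CC(=O)O1)OC(C)=O` gives 4000 nM, so compound 2 stands level with its mirror image, within the scatter. For the measured compounds named here, the only measured step is a 1.1-fold higher number from compound 1 to compound 2 (0.02 log units; within the scatter), and it goes with the fact that compounds 1 and 2 differ only in the configuration as drawn. The acetoxy group is present on both sides of that step, so the step bears only indirectly on what comes next.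

Compound 3 `CCCCCCCCCCCCCCC[C@@H](O)C[C@H](O)C[C@H](O)C[C@H](O)C[C@H](O)C[C@@H]1CC=CC(=O)O1` departs from compound 2 by a single change, hydrogen in place of acetyl on an oxygen on a saturated carbon, or acetoxy to hydroxy. Going by the values given here, no measured pair tests this change, so the data fix neither its size nor its direction. With compound 2 at 4000 nM as the anchor, no shift beyond the scatter is firmly expected in this assay, and the range is kept wide on both sides. The expected change is small, estimated as a 1.1-fold higher number from compound 2 to compound 3 (0.05 log units; within the scatter). For compound 3 the estimated value is 4500 nM, with an expected range from 1500 nM to 14000 nM.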

Compound 3, half-maximal inhibitory concentration: 7900 nM
Estimate against measurement, compound 3: 1.8-fold (0.24 log units) below, and the stated range covers the measured number.
By their numbers in this assay, from the lowest: compounds 1, 2 and 3 (each within the scatter of the next, the first and the last beyond it).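

The acetoxy to hydroxy change, hydrogen in place of acetyl on an oxygen on a saturated carbon whose other neighbours are saturated chain carbon, now has a measured pair in this assay (a 2.0-fold higher number from compound 2 to compound 3 (0.30 log units; within the scatter)). The earlier compounds shown here both carried the acetoxy group and so could say nothing about this position, whereas this pair shows that the acetyl, with its 3 heavy atoms, can give way to hydrogen without a step beyond the scatter, and that a free hydroxy at this place is compatible with cytotoxicity in the same range as compound 2. Nothing at hand bears on why this pair behaves as it does: the one available fact concerns configuration, not the acetyl group.

The compounds shown leave open whether the same change gives a comparable step on the mirror-image configuration of compound 1, as this reading rests on a single pair. They also leave open how other groups on this oxygen would read in this assay, such as a methyl ether, a benzoate ester or an amine in place of the hydroxy.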